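The compounds below may be only part of what the source reports. "The series", "measured", "known", "first", "only" and "open" are said of these compounds alone.

Measured so far:
- compound 1, `Cc1noc(-c2nc(C)c3c(c2N)C(=O)N(Cc2ccc(-n4cccn4)cc2)C3=O)n1` — in a physicochemical assay for solubility, using the shake flask method, in simulated intestinal fluid, measured as kinetic solubility, with a stated time of 2 h, at 25 degrees C, at pH 6.5 (on this read-out higher numbers stand for higher solubility and lower numbers for lower solubility), compound 1 gives < 5000 nM
- compound 2, `COc1cccc(CN2C(=O)c3c(C)nc(-c4nc(C)no4)c(N)c3C2=O)c1` — compound 2 gives < 5000 nM
- compound 3, `Cc1noc(-c2nc(C)c3c(c2N)C(=O)N(Cc2ccc(S(C)(=O)=O)cc2)C3=O)n1` — compound 3 gives < 5000 nM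

The value for compound 1 is a limit of the assay, not a number. The value for compound 2 is likewise a limit. The value for compound 3 is also a limit. Compound 1 therefore stands at the reporting limit together with the other two, and no order among the three can be read, because of the limit of < 5000 nM in this assay, at which 3 of the 3 values shown sit.

The two single-point changes measured in this set, a step that the two limits leave unreadable from compound 1 to compound 3 (methylsulfonyl in place of 1H-pyrazol-1-yl on an aromatic carbon) and a step that the two limits leave unreadable from compound 2 to compound 3 (4-(methylsulfonyl)phenyl in place of 3-methoxyphenyl on a saturated chain carbon bound to an amide-type nitrogen in a ring), both run between limits and give no readable size.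

Compound 4, `Cc1noc(-c2nc(C)c3c(c2N)C(=O)N(Cc2ccc(C#N)cc2)C3=O)n1`, differs from compound 1 as follows: cyano in place of 1H-pyrazol-1-yl on an aromatic carbon. The step from compound 1 to compound 3 alters the same aromatic carbon and stays at the limit, so nothing measured points to a step beyond the scatter in this assay. The expected step is a step that the limit leaves unreadable from compound 1 to compound 4. Compound 4 is therefore estimated at 3000 nM, in the range 500 nM to 6000 nM, most likely again reported only as a limit.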

Compound 4, solubility: < 5000 nM
Compound 4 was reported as a limit; the forecaster's own chance of this, stated with the estimate: 80%; the middle value lies beyond the limit too.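

In this assay compound 4 gives < 5000 nM, which is a limit and not a number. The steps to compound 4 from compound 1, compound 2 and compound 3 cannot be read, because all four compounds sit at the same limit: the limit of < 5000 nM in this assay, at which 4 of the 4 values shown sit.

The compounds shown leave open how their solubilities rank and whether any of these single-place changes alters the read-out.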